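Methyl Sulfonyl in Place of Fluorophenyl Sulfonyl

The source may report more compounds than this note shows. Statements on the series, on what has been measured and on what is new or still open speak of the compounds shown alone.

Compound 1 `Nc1ccc(OCc2cn(-c3cc(=O)oc4ccc(Br)cc34)nn2)cc1` gives 2090 nM in a functional assay on SW480 cells (Homo sapiens) for antiproliferative activity, read by MTT assay, with a stated time of 48 h (a higher number here means a weaker inhibitor, a lower number a stronger inhibitor), and compound 2 `COC(=O)c1ccc(OCc2cn(-c3cc(=O)oc4ccc(Br)cc34)nn2)cc1` gives 3620 nM in this assay. Going by the values given here, the only measured step, a 1.7-fold higher number from compound 1 to compound 2 (0.24 log units; within the scatter), concerns a part of the shared core far from the sulfonyl sulfur. Compound 3 `O=c1cc(-n2cc(COc3ccccc3)nn2)c2ccc(OS(=O)(=O)c3ccc(F)cc3)cc2o1` is known differently: in this assay compound 3 returns only a limit, > 50000 nM, and not a measured number. That limit is the limit of > 50000 nM in this assay, at which 1 of the 3 values shown sits. Compound 4 `CS(=O)(=O)Oc1ccc2c(-n3cc(COc4ccccc4)nn3)cc(=O)oc2c1` differs from compound 3 by methyl in place of 4-fluorophenyl on a sulfonyl sulfur. Among the compounds with values here, no measured step bears on a change at the sulfonyl sulfur, so the measured data give neither direction nor size for this step. With compound 3 fixed only at a limit, the step from compound 3 to compound 4 cannot be anchored to a number, and compound 4 is expected to stay near the same region, the expected step being an at least 1.2-fold lower number from compound 3 to compound 4 (0.09 log units; that floor lies within the scatter) with wide uncertainty. Compound 4 is therefore estimated at 40000 nM, with a range from 8000 nM to 200000 nM, and a fair chance that again only a limit is recorded.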

Compound 4, half-maximal inhibitory concentration: 10700 nM
Compound 4: the middle estimate sits 3.7-fold (0.57 log units) above what was measured; low and high end bracket the measured number.
By their numbers in this assay, from the lowest: compounds 1 and 2 (each within the scatter of the next); then compound 4. At a limit, above all of these: compound 3.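

Going by these compounds alone, at the sulfonyl sulfur, methyl in place of 4-fluorophenyl moves the number clearly, which the earlier compounds could not show: in this assay the step is an at least 4.6-fold lower number from compound 3 to compound 4 (0.66 log units; beyond the scatter). Within the data shown here, this places a change beyond the scatter at the sulfonyl sulfur, whereas the only earlier step, on a different part of the molecule, stayed within it. The size of the new step is only a floor, because compound 3 stands at a limit and not at a number: the limit of > 50000 nM in this assay, at which 1 of the 4 values shown sits.

The compounds shown leave open the full size of this step and how the number would respond to an amine or a longer chain on the sulfonyl sulfur. They also leave open whether the same change would act alike on the core of compound 1.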